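A few compounds are considered here, and "the series" means these few. Any claim that something is new, unique, unknown or untested is made for them only; others in the source may bear on it.

Three compounds share one core and differ only in the aryl group carried on the five-membered aromatic ring. Compound 1 `Oc1ccccc1/C=N/c1nnc(SCc2nnc(-c3ccc(F)cc3)o2)s1` gives 15600 nM in a functional assay on MCF7 cells (Homo sapiens) for inhibition, read by CCK-8 assay; on this read-out lower numbers stand for stronger inhibition and higher numbers for weaker inhibition. Compound 2 `Oc1ccccc1/C=N/c1nnc(SCc2nnc(-c3ccccc3Cl)o2)s1` gives 18100 nM, and compound 3 `Oc1ccccc1/C=N/c1nnc(SCc2nnc(-c3ccccc3Br)o2)s1` gives 9140 nM. Compound 3 thus stands at the low end of the three numbers, yet its steps to the others, a 1.7-fold lower number from compound 1 to compound 3 (0.23 log units; within the scatter) and a 2.0-fold lower number from compound 2 to compound 3 (0.30 log units; within the scatter), both fall within the scatter, so nothing separates it from compound 1 or compound 2.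

Compound 4 `Oc1ccccc1/C=N/c1nnc(SCc2nnc(-c3ccc(Br)cc3)o2)s1` has not yet been measured. It differs from compound 3 by 4-bromophenyl in place of 2-bromophenyl on an aromatic carbon. Two measured steps, a 1.2-fold higher number from compound 1 to compound 2 (0.06 log units; within the scatter) and a 1.7-fold lower number from compound 1 to compound 3 (0.23 log units; within the scatter), replace a 4-fluorophenyl with a 2-chlorophenyl or a 2-bromophenyl and so bear on this change; neither reaches beyond the scatter. Going by the values given here, the one step exchanging bromo for chloro, a 2.0-fold lower number from compound 2 to compound 3 (0.30 log units; within the scatter), is also within the scatter. For compound 4 the account therefore expects no step beyond the scatter in this assay, a 1.3-fold higher number from compound 3 to compound 4 (0.12 log units; within the scatter). Compound 4 is estimated at 12000 nM, with a range from 5000 nM to 30000 nM.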

Compound 4, half-maximal inhibitory concentration: 8320 nM
The estimate for compound 4 lay 1.4-fold (0.16 log units) above the measured number, within the range that was stated.
By their numbers in this assay, from the lowest: compounds 4, 3, 1 and 2 (each within the scatter of the next, the first and the last beyond it).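

The exchange of 2-bromophenyl for 4-bromophenyl on the five-membered aromatic ring gives no separable change in this assay (a 1.1-fold lower number from compound 3 to compound 4 (0.04 log units; within the scatter)), so this assay does not distinguish these two bromophenyl groups. Against the 2-chlorophenyl of compound 2, the 4-bromophenyl gives the first step in this set to pass beyond the scatter, though only a modest one (a 2.2-fold lower number from compound 2 to compound 4 (0.34 log units; beyond the scatter)), whereas bromo in place of fluoro stays within it (a 1.9-fold lower number from compound 1 to compound 4 (0.27 log units; within the scatter)). Nothing available explains any of these steps.

Every aryl group shown carries a single halogen, so it remains open how an unsubstituted phenyl, a methoxy group or a carboxylic acid on that ring would read in this assay. Also open, going by these compounds, is whether an amine or a longer alkyl chain could stand in place of the aryl group at this position.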